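A few compounds are considered here, and "the series" means these few. Any claim that something is new, unique, unknown or untested is made for them only; others in the source may bear on it.

Three compounds share one core and differ only in the aryl group hung on the carbon with a double bond to nitrogen. Compound 1 `O=C(COc1cccc2ccccc12)N/N=C/c1ccc(O)cc1` carries a 4-hydroxyphenyl there; in a physicochemical assay for lipophilicity, measured as octanol-water partition (on this read-out lower numbers stand for lower lipophilicity and higher numbers for higher lipophilicity), compound 1 gives 3.73. Compound 2 `C/C(=N\NC(=O)COc1cccc2ccccc12)c1ccc(Cl)cc1` carries a 4-chlorophenyl and in this assay compound 2 gives 4.17. Compound 3 `C/C(=N\NC(=O)COc1cccc2ccccc12)c1cccc([N+](=O)[O-])c1` carries a 3-nitrophenyl and in this assay compound 3 gives 3.37. Among the three numbers compound 1 stands second highest, beyond the scatter from each neighbour.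

The compound to be measured is compound 4 `CSc1ccc(/C=N/NC(=O)COc2cccc3ccccc23)cc1`. Compared with compound 1 the change is methylsulfanyl in place of hydroxy on an aromatic carbon. Among the compounds with values here, no measured step repeats this exchange. Within the data shown here, the only step on record, a number 0.80 log units lower from compound 2 to compound 3 (beyond the scatter), swaps one substituted phenyl for another and shows that such a swap can move this assay by a modest amount. That step offers no direct guide for methylsulfanyl in place of hydroxy, so the expectation rests on the groups themselves as counted above.

For compound 4 the expected step is a number 1.17 log units higher from compound 1 to compound 4 (beyond the scatter), a rise beyond the scatter. Compound 4 is therefore estimated at 4.9, with a likely range from 4.4 to 5.4.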

Compound 4, partition coefficient: 4.11
Estimate against measurement, compound 4: 0.79 log units above, and the stated range ends above it.
By their numbers in this assay, from the lowest: compound 3; then compound 1; then compounds 4 and 2 (each within the scatter of the next).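

In this assay, within the data shown here, methylsulfanyl in place of hydroxy on the aromatic carbon para to a large group gives a number 0.38 log units higher from compound 1 to compound 4 (beyond the scatter), the first measured step in which the group changes while its place on the ring stays the same. Among these compounds, the only earlier step, from 4-chlorophenyl to 3-nitrophenyl, changed the group and its place together, so this result shows that an exchange at this one position can by itself move the read-out beyond the usual scatter. The exchange removes the hydrogen-bond donor of hydroxy and adds a heavy atom, but no measurement at hand links the size of the step to either of these differences or to anything else about the two groups.

The compounds shown leave open whether methoxy or an amine in the same place would give a number closer to that of compound 1 or that of compound 4, and whether a longer chain on the sulfur, such as ethylsulfanyl, would go further. They also leave open whether the same exchange gives a similar step when a methyl sits on the carbon with a double bond to nitrogen, as it does in compound 2 and compound 3.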